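Swapping the Alkyl-Bearing Phenyl Ring on the Triazole

The compounds below may be only part of what the source reports. "The series", "measured", "known", "first", "only" and "open" are said of these compounds alone.

Measured so far:
Compound 1 `COc1cccc(-n2cc(COc3cccc(NC(=O)Nc4ccc(Cl)c(C(F)(F)F)c4)c3)nn2)c1` gives 1310 nM in a functional assay on HepG2 cells (Homo sapiens) for inhibition, read by MTT assay, with a stated time of 72 h; on this read-out higher numbers stand for weaker inhibition and lower numbers for stronger inhibition.
Compound 2 `CCc1cccc(-n2cc(COc3cccc(NC(=O)Nc4ccc(Cl)c(C(F)(F)F)c4)c3)nn2)c1` gives 37900 nM in this assay.
Compound 3 `CC(C)c1ccccc1-n1cc(COc2cccc(NC(=O)Nc3ccc(Cl)c(C(F)(F)F)c3)c2)nn1` is not yet measured.

Among the two measured compounds, compound 2 stands at the highest number, which here means the weakest inhibition. Going by the values given here, the only measured step leads to it: a 29-fold higher number from compound 1 to compound 2 (1.46 log units; beyond the scatter).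

Compound 3 differs from compound 2 by 2-isopropylphenyl in place of 3-ethylphenyl on an aromatic nitrogen. Among the compounds with values here, no measured step touches an isopropyl group or this position on the phenyl ring, so the single step available is only a loose guide. It shows that an alkyl group in place of methoxy left a weak compound; compound 3 carries another alkyl group, so a weak value is the simplest expectation, with wide uncertainty in both directions. The estimated step is a 1.5-fold lower number from compound 2 to compound 3 (0.18 log units; within the scatter), meaning no firm change beyond the scatter is expected. Compound 3 is therefore estimated at 25000 nM, with a range from 5000 nM to 100000 nM.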

Compound 3, half-maximal inhibitory concentration: 1900 nM
For compound 3 the middle estimate is 13-fold (1.12 log units) above the measured one; the whole stated range lies above it.
By their numbers in this assay, from the lowest: compounds 1 and 3 (each within the scatter of the next); then compound 2.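

The step to 2-isopropylphenyl gives a 20-fold lower number from compound 2 to compound 3 (1.30 log units; beyond the scatter) in this assay, so an alkyl group on this phenyl ring does not by itself leave a compound as weak as compound 2. Set against 3-methoxyphenyl, the same change gives a 1.5-fold higher number from compound 1 to compound 3 (0.16 log units; within the scatter), so on these numbers compound 1 and compound 3 cannot be told apart, even though one carries methoxy and the other an alkyl group. The large gap between the two alkyl compounds shows that this position responds strongly to the exact group, but nothing measured here explains that gap.

The groups 3-ethylphenyl and 2-isopropylphenyl differ both in the alkyl group and in its place on the ring, and the compounds shown do not separate these two changes. As far as these compounds go, how an amine, a carboxylic acid or a longer alkyl chain on this phenyl ring would behave also stays open.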